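The source may hold more compounds than are shown below. What is called first, only, known or untested is meant among the compounds shown, and "the series" means these compounds.

Measured in a functional assay on HCT-116 cells (Homo sapiens) for cytotoxicity, read by sulforhodamine B assay; on this read-out higher numbers stand for an effect only at larger amounts of compound and lower numbers for an effect already at smaller amounts:
- compound 1 `CCCCCCCCCCCCC/C=C/[C@@H](O)[C@H](CO)n1cc(CCC)nn1` gives 16000 nM
- compound 2 `CCCCCCCCCCCCC/C=C/[C@@H](O)[C@H](CO)n1cc(CCCCCCCCCCCCC)nn1` gives > 50000 nM, which is a limit and not a number

Compound 2 therefore has no exact position and stands only at the limit of > 50000 nM in this assay, at which 1 of the 2 values shown sits, so any step starting from it is uncertain.

Compound 3 `CCCCCCCCCCCCC/C=C/[C@@H](O)[C@H](CO)n1cc(CCCCCC)nn1` differs from compound 2 by one change in the chain: hydrogen in place of heptyl on a saturated chain carbon, six bonds along the chain from an aromatic carbon.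

Going by the values given here, only one measured step bears on this change. That step, an at least 3.1-fold higher number from compound 1 to compound 2 (0.49 log units; beyond the scatter), added decyl to the same chain and moved the reading to a higher number. The new change runs the opposite way and removes only part of that added length, so a modest move to a lower number is expected, though this rests on a single step. The expected change is an at least 2.0-fold lower number from compound 2 to compound 3 (0.30 log units; that floor lies within the scatter), and this is only an estimate. For compound 3 the estimated value is 25000 nM, with an expected range from 10000 nM to 50000 nM, and a measurement within that range would show how much of the chain matters.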

Compound 3, half-maximal effective concentration: 12500 nM
For compound 3 the middle estimate is 2.0-fold (0.30 log units) above the measured one; low and high end bracket the measured number.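

Replacing heptyl with hydrogen on this chain brings the reading in this assay back within measurable range, with an at least 4.0-fold lower number from compound 2 to compound 3 (0.60 log units; beyond the scatter). Set against compound 1, however, the chain of compound 3 makes no clear difference, with a 1.3-fold lower number from compound 1 to compound 3 (0.11 log units; within the scatter), so these two compounds cannot be told apart on this read-out. Among these three compounds, then, a longer chain at this place does not by itself shift the reading: the move to a higher number appears only on going from the chain of compound 3 to the much longer one of compound 2, and compound 2 gives only a limit, so the true size of that move stays unknown: the limit of > 50000 nM in this assay, at which 1 of the 3 values shown sits.

Going by these compounds, what remains open is where along the stretch of chain lengths from compound 3 to compound 2 the reading starts to rise, and whether it does so gradually or sharply. On these data alone, it is equally open how this place would respond to something other than a plain carbon chain, such as a chain ending in an amine or a carboxylic acid, or a phenyl group.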